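This account rests on a few compounds, and the source may have more. Where it says the series, first, only, none or still open, it means among the compounds named here.

Working notes on the series, read in a functional assay on DU-145 cells (Homo sapiens) for cytotoxicity, read by MTT assay; a lower number here means a stronger inhibitor, a higher number a weaker inhibitor. Among the measured compounds shown here, compound 3 `CC(C)=CC[C@@H](OC(=O)C1CCOC1)C1=CC(=O)c2c(O)ccc(O)c2C1=O` gives 47500 nM, the only true number so far. Compound 1 `CC(C)=CC[C@@H](OC(=O)c1ccco1)C1=CC(=O)c2c(O)ccc(O)c2C1=O` reads > 100000 nM, which is an assay limit. Compound 2 `CCCC(O)CC(=O)O[C@H](CC=C(C)C)C1=CC(=O)c2c(O)ccc(O)c2C1=O` reads > 100000 nM, also a limit. Compound 4 `CC(C)=CC[C@@H](OC(=O)C1CCCCO1)C1=CC(=O)c2c(O)ccc(O)c2C1=O` differs from compound 3 by oxan-2-yl in place of oxolan-3-yl on a carbonyl carbon, with oxan-2-yl in place of oxolan-3-yl on a carbonyl carbon. Two measured steps change the same place: an at least 2.1-fold lower number from compound 1 to compound 3 (0.32 log units; beyond the scatter) and an at least 2.1-fold lower number from compound 2 to compound 3 (0.32 log units; beyond the scatter). Each is bounded by a limit, and neither involves oxan-2-yl, so they show only that this place can shift the read-out. The expected step is a 1.3-fold higher number from compound 3 to compound 4 (0.10 log units; within the scatter), with no clear change beyond the scatter. The estimate for compound 4 is 60000 nM, within a range of 25000 nM to 100000 nM.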

Compound 4, half-maximal inhibitory concentration: 24700 nM
Compound 4: the middle estimate sits 2.4-fold (0.39 log units) above what was measured, and the stated range ends above it.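

In this assay, oxan-2-yl in place of oxolan-3-yl on the carbonyl carbon gives a 1.9-fold lower number from compound 3 to compound 4 (0.28 log units; within the scatter), so these two non-aromatic oxygen rings are not told apart at this position. Compound 4 adds a second true number here and stands apart from the other two groups, with an at least 4.0-fold lower number from compound 2 to compound 4 (0.60 log units; beyond the scatter) and an at least 4.0-fold lower number from compound 1 to compound 4 (0.60 log units; beyond the scatter). Those two steps are bounded on one side only: the limit of > 100000 nM in this assay, at which 2 of the 4 values shown sit.

The pair of compound 3 and compound 4 does not separate ring size from point of attachment. On these data alone, how an amine in this place would read remains open.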